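Swapping Methyl for Chloro: Expected Cytotoxicity of Compound 4

The source may report more compounds than this note shows. Statements on the series, on what has been measured and on what is new or still open speak of the compounds shown alone.

Of the compounds shown here, three built on a shared core have been tested in a functional assay on HEp-2 cells (Homo sapiens) for cytotoxicity, read by MTT assay; on this read-out lower numbers stand for stronger inhibition and higher numbers for weaker inhibition. Compound 1 `CC1=NNC(=O)C1C(c1c(-c2ccccc2)[nH]c2ccc(C)cc12)c1c(-c2ccccc2)[nH]c2ccc(Cl)cc12` gives 32400 nM. Compound 2 `CC1=NNC(=O)C1C(c1c(-c2ccccc2)[nH]c2ccc(Cl)cc12)c1c(-c2ccccc2)[nH]c2ccc(Cl)cc12` gives 14600 nM. Compound 3 `CC1=NNC(=O)C1C(c1c[nH]c2ccccc12)c1c(-c2ccccc2)[nH]c2ccc(C)cc12` gives 3200 nM, the lowest of the three numbers.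

The change from compound 1 to compound 2 is chloro in place of methyl on an aromatic carbon, and it produced a 2.2-fold lower number from compound 1 to compound 2 (0.35 log units; beyond the scatter). How the core of compound 3 differs from the core of compound 1 is not broken down here.

Compound 4 `CC1=NNC(=O)C1C(c1c[nH]c2ccccc12)c1c(-c2ccccc2)[nH]c2ccc(Cl)cc12` has not yet been measured. It differs from compound 3 by chloro in place of methyl on an aromatic carbon, the same change that was made from compound 1 to compound 2, at a place described in the same words. Within the data shown here, the step to compound 4 is expected to be a 1.9-fold lower number from compound 3 to compound 4 (0.27 log units; within the scatter), estimated from the single earlier example of this change because that example gave a 2.2-fold lower number from compound 1 to compound 2 (0.35 log units; beyond the scatter). Compound 4 is therefore expected to give about 1700 nM in this assay. The estimate for compound 4 is expected to fall between 700 nM and 4500 nM.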

Compound 4, half-maximal inhibitory concentration: > 100000 nM
Compound 4 ended at the assay's limit; the forecaster's own chance of this, stated with the estimate: 5%; at least 58-fold (1.76 log units) between middle value and limit.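

In this assay, chloro in place of methyl on an aromatic carbon gives an at least 31-fold higher number from compound 3 to compound 4 (1.49 log units; beyond the scatter), so this step runs in the opposite direction to the earlier one and the two do not agree: the same change on two cores in this assay, a 2.2-fold lower number (0.35 log units; beyond the scatter) from compound 1 to compound 2 and an at least 31-fold higher number (1.49 log units; beyond the scatter) from compound 3 to compound 4, at least 69-fold (1.84 log units) apart, beyond the scatter of two such steps

Compound 4 gives > 100000 nM, which is a limit of the assay and not a number: the limit of > 100000 nM in this assay, at which 1 of the 4 values shown sits.

This shows that the effect of the change did not carry over from the core of compound 1 to the core of compound 3, but it does not show why, and two pairs of compounds give no rule for any other core.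

The compounds shown leave open whether this split belongs to chloro alone or would also appear with another group in the same place, such as fluoro, methoxy or an amine. From the compounds shown here alone, it also remains open how the same swap would behave on a third core.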